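Configuration and half-life: from compound 2 to compound 3

The compounds below may be only part of what the source reports. "The series", "measured", "known", "first", "only" and "open" are said of these compounds alone.

Measured in an ADME assay on Jejunum (Mus musculus, strain C57BL/6) for metabolic stability, read by HPLC, with a stated time of 12 h; on this read-out higher numbers stand for a longer-lived compound and lower numbers for a shorter-lived compound:
- compound 1 (`O=C(O)[C@H](CO)NC(=O)[C@H]1C[C@@H](O)CN1`): > 12 h, a limit of the assay
- compound 2 (`O=C(N[C@H](CO)C(=O)O)[C@@H]1C[C@@H](O)CN1`): 0.39 h

Going by the values given here, compound 2 holds the only actual number in this assay. Compound 1 gives only a limit (the limit of > 12 h in this assay, at which 1 of the 2 values shown sits).

Compound 3 (`O=C(O)[C@H](CO)NC(=O)[C@@H]1C[C@@H](O)CN1`) departs from compound 2 in one place (the two compounds have the same atoms and bonds and differ only in configuration as drawn: 1 of 3 stereo elements differ; a stereocentre at a saturated chain carbon is drawn R in compound 2 and S in compound 3). The saturated chain carbon is thus drawn S as in compound 1, while the saturated ring carbon stays drawn S as in compound 2.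

Among the compounds with values here, the one measured step (an at least 30-fold lower number from compound 1 to compound 2 (1.48 log units; beyond the scatter)) is large, but it rests on the fact that compounds 1 and 2 differ only in the configuration as drawn and changes both centres at once, so the data do not separate them. Compound 3 keeps the ring centre of compound 2 (0.39 h), so no change beyond the scatter is expected, though the uncertainty is wide. The expected step is small (a 1.1-fold lower number from compound 2 to compound 3 (0.05 log units; within the scatter)). For compound 3 the estimated half-life is 0.35 h (expected range 0.1 h to 2 h).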

Compound 3, half-life in the Mus musculus assay: 0.29 h
Beside the measured number, compound 3's estimate is 1.2-fold (0.08 log units) above it; measured number inside the range.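

In the Mus musculus assay, changing the saturated chain carbon alone stays within the scatter: a 1.3-fold lower number from compound 2 to compound 3 (0.13 log units; within the scatter). Changing the saturated ring carbon alone gives a large step, an at least 41-fold lower number from compound 1 to compound 3 (1.61 log units; beyond the scatter), so among these compounds the earlier two-centre step follows the ring stereocentre. In a physicochemical assay for metabolic stability, read by HPLC, in phosphate buffer, with a stated time of 12 h, at pH 6.8 (a lower number here means that the compound disappears faster, a higher number that the compound lasts longer), compound 2 gives > 12 h, a limit of the assay. In the physicochemical assay, compound 3 gives > 12 h, also a limit of the assay. In the physicochemical assay, the step between compound 2 and compound 3 cannot be read, as both values sit at a limit: the limit of > 12 h in the physicochemical assay, at which 2 of the 2 values shown sit.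

As far as these compounds go, the effect of the chain carbon with the ring carbon drawn R remains open. So does whether a methyl ester in place of the carboxylic acid keeps this dependence on the ring stereocentre.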